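Sulfonamide replacing the furoyl amide on the shared core

This account rests on a few compounds, and the source may have more. Where it says the series, first, only, none or still open, it means among the compounds named here.

Three compounds sharing one core differ only in the group on a nitrogen on an aromatic ring. In a functional assay on RAW264.7 cells (Mus musculus) for inhibition, read by ELISA, with stated times of 30 min and 24 h (on this read-out lower numbers stand for stronger inhibition and higher numbers for weaker inhibition), compound 1 `CN1CCN(c2ccc(NC(=O)c3cc4cc(NC(=O)CCl)ccc4n3Cc3ccc(C(F)(F)F)cc3)cc2)CC1` gives 2990 nM, compound 2 `CN1CCN(c2ccc(NC(=O)c3cc4cc(NC(=O)N(C)C)ccc4n3Cc3ccc(C(F)(F)F)cc3)cc2)CC1` gives 1240 nM and compound 3 `CN1CCN(c2ccc(NC(=O)c3cc4cc(NC(=O)c5ccco5)ccc4n3Cc3ccc(C(F)(F)F)cc3)cc2)CC1` gives 2900 nM. Compound 3 stands second highest of the three: its number and that of compound 1 lie within the scatter of each other, while a 2.3-fold higher number from compound 2 to compound 3 (0.37 log units; beyond the scatter). Compound 4 `CN1CCN(c2ccc(NC(=O)c3cc4cc(NS(C)(=O)=O)ccc4n3Cc3ccc(C(F)(F)F)cc3)cc2)CC1` carries methylsulfonyl in place of (furan-2-yl)carbonyl on a nitrogen on an aromatic ring. The steps at this position bear on it: a 1.0-fold lower number from compound 1 to compound 3 (0.01 log units; within the scatter) and a 2.4-fold lower number from compound 1 to compound 2 (0.38 log units; beyond the scatter). Changes here have so far moved this assay by modest amounts at most, and no sulfonamide precedent exists in the set. A step near the scatter in this assay is therefore expected, a 1.2-fold lower number from compound 3 to compound 4 (0.06 log units; within the scatter). Compound 4 is estimated at 2500 nM, between 800 nM and 8000 nM.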

Compound 4, half-maximal inhibitory concentration: 4910 nM
Estimate against measurement, compound 4: 2.0-fold (0.29 log units) below, and the stated range covers the measured number.
By their numbers in this assay, from the lowest: compound 2; then compounds 3, 1 and 4 (each within the scatter of the next).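

In this assay, among the compounds shown here, methylsulfonyl, the only group here without a carbonyl on this nitrogen, stays within the scatter of both carbonyl-linked groups (a 1.7-fold higher number from compound 3 to compound 4 (0.23 log units; within the scatter); a 1.6-fold higher number from compound 1 to compound 4 (0.22 log units; within the scatter)). Dimethylcarbamoyl alone stands apart, and the gap to methylsulfonyl is the widest step at this position (a 4.0-fold higher number from compound 2 to compound 4 (0.60 log units; beyond the scatter)), so losing the carbonyl link does not separate compound 4 from compound 1 or compound 3. No supporting measurement accounts for these steps. Open, as far as these compounds go, is whether a free amine, a phenylsulfonyl group or a larger urea such as piperidine-1-carbonyl on this nitrogen would follow compound 2 or compound 4.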